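From vinyl to prop-1-en-1-yl on compound 3

A few compounds are considered here, and "the series" means these few. Any claim that something is new, unique, unknown or untested is made for them only; others in the source may bear on it.

Values in a functional assay on A549 cells (Homo sapiens) for antiproliferative activity, read by MTT assay, with a stated time of 72 h; a lower number here means a stronger inhibitor, a higher number a weaker inhibitor:
- Compound 1 `C=CC(=O)Nc1cccc(Oc2nc(Nc3ccn(C)n3)nc3c2CSCC3)c1`: 18600 nM
- Compound 2 `C/C=C/C(=O)Nc1cccc(Oc2nc(Nc3ccn(C)n3)nc3c2CSCC3)c1`: > 50000 nM
- Compound 3 `C=CC(=O)Nc1cccc(Oc2nc(Nc3cccc(OC)c3)nc3c2CSCC3)c1`: 10100 nM
- Compound 4 `C/C=C/C(=O)Nc1cccc(Oc2nc(Nc3cccc(OC)c3)nc3c2CSCC3)c1`: not yet measured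

The value of compound 2 is a limit, not a number. Among the measured compounds shown here, the only two true numbers cannot be told apart, as the gap is a 1.8-fold lower number from compound 1 to compound 3 (0.27 log units; within the scatter). Compound 4 differs from compound 3 by one swap on the carbonyl carbon: prop-1-en-1-yl in place of vinyl on a carbonyl carbon. The same swap has been measured once, as an at least 2.6-fold higher number from compound 1 to compound 2 (0.42 log units; beyond the scatter). A step in the same direction, towards a higher number, is therefore expected in this assay, and it may reach the limit. The expected change is a 3.5-fold higher number from compound 3 to compound 4 (0.54 log units; beyond the scatter). Compound 4 is estimated at 35000 nM, with an expected range from 20000 nM to 60000 nM.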

Compound 4, half-maximal inhibitory concentration: 21100 nM
The estimate for compound 4 lay 1.7-fold (0.22 log units) above the measured number, within the range that was stated.
By their numbers in this assay, from the lowest: compounds 3, 1 and 4 (each within the scatter of the next, the first and the last beyond it). At a limit, above all of these: compound 2.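

In this assay, the swap of vinyl to prop-1-en-1-yl on the carbonyl carbon now has a true size, a 2.1-fold higher number from compound 3 to compound 4 (0.32 log units; beyond the scatter), and the number rises on both cores shown, though only one step can be sized: the same change on two cores in this assay, an at least 2.6-fold higher number (0.42 log units; beyond the scatter) from compound 1 to compound 2 and a 2.1-fold higher number (0.32 log units; beyond the scatter) from compound 3 to compound 4; the limit leaves it open whether they differ. With prop-1-en-1-yl in place, 3-methoxyphenyl in place of 1-methyl-1H-pyrazol-3-yl gives an at least 2.3-fold lower number from compound 2 to compound 4 (0.37 log units; beyond the scatter), a step that starts from a limit and lies beyond the scatter, but the two readings of this swap cannot be compared closely: the same change on two cores in this assay, a 1.8-fold lower number (0.27 log units; within the scatter) from compound 1 to compound 3 and an at least 2.3-fold lower number (0.37 log units; beyond the scatter) from compound 2 to compound 4; the limit leaves it open whether they differ.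

On these data alone, it remains open how a longer chain on the double bond, or a dimethylaminomethyl group there, would shift the number.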